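A few compounds are considered here, and "the series" means these few. Any claim that something is new, unique, unknown or untested is made for them only; others in the source may bear on it.

Three members of the series share one core and have been read in a functional assay on DU-145 cells (Homo sapiens) for inhibition, read by trypan blue exclusion, with a stated time of 96 h (on this read-out higher numbers stand for weaker inhibition of growth and lower numbers for stronger inhibition of growth), so far. Compound 1 `Cc1ccsc1/C=C(/SCc1ccc(Cl)cc1)C(=O)c1ccc(Cl)cc1` gives 50000 nM in this read-out. Compound 2 `O=C(/C(=C\c1ccc(O)cc1O)SCc1ccc(Cl)cc1)c1ccc(Cl)cc1` gives 50000 nM here, and the step between them is no change at the digits printed from compound 1 to compound 2 (within the scatter). Compound 3 `CN(C)c1ccc(/C=C(/SCc2ccc(Cl)cc2)C(=O)c2ccc(Cl)cc2)cc1` has no number, only the limit > 100000 nM. It stands at the limit of > 100000 nM in this assay, at which 1 of the 3 values shown sits.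

Compound 4 `COc1ccc(/C=C(/SCc2ccc(Cl)cc2)C(=O)c2ccc(Cl)cc2)cc1` follows from compound 3 by one change: methoxy in place of dimethylamino on an aromatic carbon, para to a large group. Two measured steps end at the same place in compound 3: an at least 2.0-fold higher number from compound 1 to compound 3 (0.30 log units; that floor lies within the scatter), and an at least 2.0-fold higher number from compound 2 to compound 3 (0.30 log units; that floor lies within the scatter). Neither isolates the methoxy group, and none of the three steps goes beyond the scatter. In this assay, going by the values given here, no large step is therefore expected, and any direction is only tentative, with a number near those of compound 1 (50000 nM) and compound 2 (50000 nM) the likeliest outcome. The estimated step is an at least 1.6-fold lower number from compound 3 to compound 4 (0.22 log units; that floor lies within the scatter). For compound 4 the expected value is 60000 nM, with an estimated range of 20000 nM to 100000 nM.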

Compound 4, concentration for 50% growth inhibition: 10000 nM
Compound 4: the middle estimate sits 6.0-fold (0.78 log units) above what was measured, outside the stated range (below it).
By their numbers in this assay, from the lowest: compound 4; then compounds 1 and 2 (each within the scatter of the next). At a limit, above all of these: compound 3.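

Methoxy in place of dimethylamino, on an aromatic carbon para to a large group, gives an at least 10-fold lower number from compound 3 to compound 4 (1.00 log units; beyond the scatter), the first step in the series beyond the scatter in this assay. The 4-methoxyphenyl group also separates from the two other groups on this carbon, with a 5.0-fold lower number from compound 2 to compound 4 (0.70 log units; beyond the scatter) and a 5.0-fold lower number from compound 1 to compound 4 (0.70 log units; beyond the scatter), so this position can move the read-out, although the values remain high. Compound 3 carries only a limit, so its step to compound 4 is a floor and its full size stays unknown: the limit of > 100000 nM in this assay, at which 1 of the 4 values shown sits.

The compounds shown leave open whether an ethoxy group or a chlorine atom in the same place would give a similar or lower number. They also leave open whether the methoxy group would hold this result on another carbon of the ring.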